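Three flat readings and a methylfuran newcomer

The compounds below may be only part of what the source reports. "The series", "measured", "known", "first", "only" and "open" are said of these compounds alone.

Measured so far:
- compound 1 `COc1ccccc1C1C(C#N)=C(N)N(c2ccc(S(N)(=O)=O)cc2)C2=C1C(=O)CCC2`: 0%
- compound 2 `COc1ccc(C2C(C#N)=C(N)N(c3ccc(S(N)(=O)=O)cc3)C3=C2C(=O)CCC3)c2ccccc12`: 10%
- compound 3 `N#CC1=C(N)N(c2ccc(S(N)(=O)=O)cc2)C2=C(C(=O)CCC2)C1c1ccco1`: 0%

All three compounds share one core and differ only in the group attached to a saturated ring carbon. In a functional assay on Ehrlich cells (Mus musculus) for antiproliferative activity, read by trypan blue exclusion, with a stated time of 2 h, tested at 10 ug/mL (a lower number here means a weaker effect, a higher number a stronger effect of the compound at the concentration tested), compound 1 gives 0%. Among the compounds with values here, it stands level with compound 3 at the digits printed, and together these two are the lowest of the three numbers; the only other compound, compound 2, lies a number 10 percentage points higher from compound 1 to compound 2 (within the scatter). Within the data shown here, none of the three readings is separated from another by more than the usual scatter, so no compound can be called stronger or weaker than the rest.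

Compound 4 `Cc1ccoc1C1C(C#N)=C(N)N(c2ccc(S(N)(=O)=O)cc2)C2=C1C(=O)CCC2` has not yet been tested. It differs from compound 1 in one place: 3-methylfuran-2-yl in place of 2-methoxyphenyl on a saturated ring carbon.

Among the measured compounds shown here, the steps that bear on this change are the earlier swaps at the same carbon. Replacing the 2-methoxyphenyl by 4-methoxynaphthalen-1-yl gave a number 10 percentage points higher from compound 1 to compound 2 (within the scatter), and replacing it by furan-2-yl gave no change at the digits printed from compound 1 to compound 3 (within the scatter). A furan ring is already represented by compound 3, and its reading matched that of compound 1. Nothing among these steps points in either direction beyond the scatter.

Compound 4 is therefore expected to give about 3%, with a range from 0% to 15%. The step expected from compound 1 is a number 3 percentage points higher from compound 1 to compound 4 (within the scatter), that is, no change beyond the scatter.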

Compound 4, a percentage reported as activity, at one concentration (the size of the read-out at that concentration, not a potency): 2%
Compound 4: middle estimate off by 1 percentage points, on the high side; measured number inside the range.
By their numbers in this assay, from the lowest: compounds 1, 3, 4 and 2 (each within the scatter of the next).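

In this assay, the saturated ring carbon also accepts 3-methylfuran-2-yl in place of 2-methoxyphenyl, a group with fewer heavy atoms and a five-membered aromatic ring, and this swap gives a number 2 percentage points higher from compound 1 to compound 4 (within the scatter). New here is a methyl in place of hydrogen on an aromatic carbon of the furan, which gives a number 2 percentage points higher from compound 3 to compound 4 (within the scatter), while the swap from the 4-methoxynaphthalen-1-yl group gives a number 8 percentage points lower from compound 2 to compound 4 (within the scatter), so neither change separates compound 4 from the compounds it is compared with. No measurement is available that could explain these readings.

The compounds shown carry only aromatic rings with a single oxygen-bearing feature at this carbon, so it remains open whether a different group there, such as a carboxylic acid, an amine or a longer alkyl chain, would move the reading beyond the usual scatter. Also open, going by these compounds, is whether changing another part of the shared core, such as the 4-sulfamoylphenyl group on the ring nitrogen or the cyano group, would have any greater effect in this assay.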